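The compounds below may be only part of what the source reports. "The series", "measured", "known", "first", "only" and "open" are said of these compounds alone.

Measured so far in an assay on HEK293 cells for agonist activity at Toll-like receptor 2 (Homo sapiens); a higher number here means that more compound is needed for the effect, a lower number that less compound is needed:

Compound 1, `CCCCCCCCCCCC(=O)OC[C@H](CSC[C@@H](N)C(=O)N[C@@H](C)CO)OC(=O)CCCCCCCCCCC`: 1560 nM
Compound 2, `CCCCCCCCCCCC(=O)OC[C@H](CSC[C@@H](N)C(=O)NCCCCCCO)OC(=O)CCCCCCCCCCC`: 33 nM
Compound 3, `CCCCCCCCCCCC(=O)OC[C@H](CSC[C@@H](N)C(=O)NCCCN)OC(=O)CCCCCCCCCCC`: 1960 nM

Compound 3 gives the highest of the three numbers; its gap to compound 1 is within the scatter, whereas a 59-fold higher number from compound 2 to compound 3 (1.77 log units; beyond the scatter) is large. Compound 4, `CCCCCCCCCCCC(=O)OC[C@H](CSC[C@@H](N)C(=O)NC(C)CCN(CC)CC)OC(=O)CCCCCCCCCCC`, is not yet measured. It differs from compound 3 by 3-(diethylamino)-1-methylpropyl in place of 3-aminopropyl on an amide-type nitrogen. For the measured compounds named here, no measured step makes this exact change. Going by the values given here, the steps that bear on it are a 59-fold higher number from compound 2 to compound 3 (1.77 log units; beyond the scatter) and a 47-fold lower number from compound 1 to compound 2 (1.67 log units; beyond the scatter), both large, both showing that the group on the amide-type nitrogen moves this assay strongly, with the longer six-carbon chain of compound 2 giving the lowest number. Because of a 59-fold higher number from compound 2 to compound 3 (1.77 log units; beyond the scatter) a lower number than compound 3 is expected, with wide uncertainty: the estimate for compound 4 is 600 nM, between 100 nM and 3500 nM, a step of a 3.3-fold lower number from compound 3 to compound 4 (0.51 log units; beyond the scatter).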

Compound 4, half-maximal effective concentration: 257 nM
Estimate against measurement, compound 4: 2.3-fold (0.37 log units) above; measured number inside the range.
By their numbers in this assay, from the lowest: compound 2; then compound 4; then compounds 1 and 3 (each within the scatter of the next).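

In this assay, a 7.6-fold lower number from compound 3 to compound 4 (0.88 log units; beyond the scatter) shows that a chain ending in an amine on the amide-type nitrogen can move the number beyond the scatter, and a 6.1-fold lower number from compound 1 to compound 4 (0.78 log units; beyond the scatter) places 3-(diethylamino)-1-methylpropyl clear of the 1-(hydroxymethyl)ethyl group as well. The 6-hydroxyhexyl group still gives the lowest number, with a 7.8-fold higher number from compound 2 to compound 4 (0.89 log units; beyond the scatter) on this change. No measurement bearing on the cause of these steps is available.

The change adds the diethylamino end and the 1-methyl branch together, so 3-(diethylamino)propyl would be needed to separate them. A 6-aminohexyl chain would show whether the six-carbon length holds with an amine at its end.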